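Chloro to methoxy on compound 2

This account rests on a few compounds, and the source may have more. Where it says the series, first, only, none or still open, it means among the compounds named here.

compound 1 `Cn1cc(C2=C(c3nn(CCCn4cccc4)c4ncccc34)C(=O)NC2=O)c2ccccc21` 21600 nM
compound 2 `Cn1cc(C2=C(c3nn(CCCN4CCCCC4)c4ncccc34)C(=O)N(c3ccc(Cl)cc3)C2=O)c2ccccc21` 1800 nM
compound 3 `CN1CCN(CCCn2nc(C3=C(c4cn(C)c5ccccc45)C(=O)NC3=O)c3cccnc32)CC1` 46700 nM

In a functional assay on K562 cells (Homo sapiens) for antiproliferative activity, read by MTT assay, with a stated time of 48 h (a higher number here means a weaker inhibitor, a lower number a stronger inhibitor), compound 2 gives 1800 nM as the lowest of the three numbers, so it is the strongest inhibitor measured so far. The next compound to consider is compound 4 `COc1ccc(N2C(=O)C(c3cn(C)c4ccccc34)=C(c3nn(CCCN4CCCCC4)c4ncccc34)C2=O)cc1`, which keeps all of compound 2 except one group. It has methoxy in place of chloro on an aromatic carbon, turning 4-chlorophenyl into 4-methoxyphenyl (methoxy in place of chloro on an aromatic carbon).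

For the measured compounds named here, only one measured step links two compounds that differ in one place (a 2.2-fold higher number from compound 1 to compound 3 (0.33 log units; beyond the scatter)). There, 4-methylpiperazin-1-yl replaces 1H-pyrrol-1-yl on the chain, a different place from the group changed here. That step was modest, though beyond the scatter, and it gives only a rough sense of how far a single swap can move the number. Going by the values given here, no measured step touches the 4-chlorophenyl group, so the data give no direction for this change. In this assay no step beyond the scatter is therefore expected (a 1.3-fold higher number from compound 2 to compound 4 (0.12 log units; within the scatter)) and the uncertainty stays wide. For compound 4 the estimated value is 2400 nM with an expected range from 800 nM to 7000 nM around it.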

Compound 4, half-maximal inhibitory concentration: > 100000 nM
Compound 4 was reported as a limit; the forecaster's own chance of this, stated with the estimate: 3%; middle value at least 41-fold (1.61 log units) away from the limit.
By their numbers in this assay, from the lowest: compound 2; then compound 1; then compound 3. At a limit, above all of these: compound 4.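

In this assay, for the compounds shown here, the change from 4-chlorophenyl to 4-methoxyphenyl gives an at least 55-fold higher number from compound 2 to compound 4 (1.74 log units; beyond the scatter), a large step at a place that no earlier pair of compounds touched. The value of compound 4 is a limit of the assay and not a number: the limit of > 100000 nM in this assay, at which 1 of the 4 values shown sits. Going by these compounds alone, the only earlier step, a 2.2-fold higher number from compound 1 to compound 3 (0.33 log units; beyond the scatter), lay on the chain and was modest, whereas this one shows that a swap of one small group for another, on an aromatic carbon para to a large group, can move the number much further, even though only one more heavy atom and one hydrogen-bond acceptor are counted on the entering side.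

From the compounds shown here alone, this single pair cannot tell whether methoxy in particular is the problem or whether chloro is hard to replace at all, so it remains open whether a fluoro, a methyl or a hydroxyl in the same place would stay close to compound 2 or fall away like compound 4. Compound 2 also differs from compound 1 and from compound 3 in more than one place, so what the 4-chlorophenyl group itself contributes is still unsettled.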